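Swapping Methyl for Chloro on the Benzyl Ring

This account rests on a few compounds, and the source may have more. Where it says the series, first, only, none or still open, it means among the compounds named here.

Compound 1 `Cc1cccc(Cn2cc(COc3ccc4c(=O)ccoc4c3)nn2)c1` is the anchor of this small set. In a functional assay on MDA-MB-231 cells (Homo sapiens) for cytotoxicity, read by MTT assay, with a stated time of 48 h (a lower number here means a stronger inhibitor, a higher number a weaker inhibitor), compound 1 gives 16000 nM, and among the three compounds measured it is the only one that returns an actual number rather than a limit. Compound 2 `O=c1ccoc2cc(OCc3cn(Cc4ccc(Cl)cc4Cl)nn3)ccc12` stops at the limit of the assay, > 100000 nM. Compound 3 `O=c1ccoc2cc(OCc3cn(Cc4ccc(F)cc4)nn3)ccc12` likewise reaches only the limit, > 100000 nM. Both replacements of the 3-methylphenyl group cost activity: an at least 6.2-fold higher number from compound 1 to compound 2 (0.79 log units; beyond the scatter) and an at least 6.2-fold higher number from compound 1 to compound 3 (0.79 log units; beyond the scatter). Compound 4 `O=c1ccoc2cc(OCc3cn(Cc4cccc(Cl)c4)nn3)ccc12` differs from compound 1 by a narrower change, (chloro in place of methyl on an aromatic carbon), so the chloro sits meta to a large group just as the methyl did. The two measured steps both point toward weaker inhibition, though each exchanged the whole ring pattern rather than a single group, so they guide only loosely. A weaker result is therefore expected for compound 4 in this assay, a step of a 2.8-fold higher number from compound 1 to compound 4 (0.45 log units; beyond the scatter). Compound 4 is estimated at 45000 nM, within a range from 12000 nM to 100000 nM, with a real chance that only the limit is reported.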

Compound 4, half-maximal inhibitory concentration: > 100000 nM
Compound 4 ended at the assay's limit; the forecaster's own chance of this, stated with the estimate: 40%; middle value at least 2.2-fold (0.34 log units) from the limit.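

With only the methyl replaced by chloro and its place on the ring unchanged, this assay shows an at least 6.2-fold higher number from compound 1 to compound 4 (0.79 log units; beyond the scatter). The earlier steps shown here exchanged the whole ring pattern, whereas this one ties the loss to a single group on an aromatic carbon, meta to a large group, so the methyl itself matters here and a chloro cannot stand in for it. The steps among compound 2, compound 3 and compound 4 cannot be read, because all three end at the same ceiling: the limit of > 100000 nM in this assay, at which 3 of the 4 values shown sit.

On these data alone, the true size of the loss stays open, since compound 4 gives only a limit and not a number. Also open, as far as these compounds go, is whether an ethyl group, a methoxy group or an amine in the same place would match or improve on compound 1.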